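Removing the Methoxymethyl Cap from a Long-Chain Carbamate

A few compounds are considered here, and "the series" means these few. Any claim that something is new, unique, unknown or untested is made for them only; others in the source may bear on it.

Compound 1 `CCCCCCCCCCCCCC[C@H](OCOC)[C@H](CN(CC)CC)NC(=O)OC(C)(C)C` was tested in a functional assay on MCF7 cells (Homo sapiens) for antiproliferative activity, read by sulforhodamine B assay, with a stated time of 48 h, tested at 10 uM (on this read-out higher numbers stand for more inhibition at the one concentration tested (going by the name of the read-out) and lower numbers for less inhibition), where compound 1 gives 25.3%. Compound 2 `CCCCCCCCCCCCCC[C@H](OCOC)[C@H](CN1CCN(C)CC1)NC(=O)OC(C)(C)C` gives 28% in this assay. Among the measured compounds shown here, the only measured step, a number 2.7 percentage points higher from compound 1 to compound 2 (within the scatter), swaps the amine end and stays within the scatter, so compound 1 stands alongside compound 2 with a gap inside the scatter. Compound 3 `CCCCCCCCCCCCCC[C@H](O)[C@H](CN(CC)CC)NC(=O)OC(C)(C)C` differs from compound 1 by hydrogen in place of methoxymethyl on an oxygen on a saturated carbon. For the measured compounds named here, no measured step touches this oxygen, so the amine step does not bear on it. The step of a number 0.3 percentage points lower from compound 1 to compound 3 (within the scatter) is therefore expected to stay within the scatter. Compound 3 is expected to give 25%, within a range from 10% to 40%.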

Compound 3, a percentage reported as inhibition, at one concentration (the size of the read-out at that concentration, not a potency): 18.7%
Compound 3: the middle estimate sits 6.3 percentage points above what was measured, and the stated range covers the measured number.
By their numbers in this assay, from the lowest: compounds 3, 1 and 2 (each within the scatter of the next).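

Hydrogen in place of methoxymethyl on this oxygen gives a number 6.6 percentage points lower from compound 1 to compound 3 (within the scatter) in this assay and so leaves the capped and the free hydroxy forms inseparable at the one concentration tested. This oxygen, like the amine end, has so far shown no change beyond the scatter. Nothing available here explains the result.

From the compounds shown here alone, whether an acetyl or a benzyl group on this oxygen would read differently stays open. So does whether the free hydroxy gives a similar reading with the 4-methylpiperazin-1-yl end of compound 2.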